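This account rests on a few compounds, and the source may have more. Where it says the series, first, only, none or still open, it means among the compounds named here.

Compound 3, `Cc1ccc(C#N)c(OC(C)(C)C2OCC(C/C=C\CCC(=O)O)C(c3cccnc3)O2)c1`, stands lowest of the three numbers measured in a functional assay for inhibition, with Homo sapiens as the target; on this read-out higher numbers stand for weaker binding and lower numbers for tighter binding: compound 3 gives 15.9 nM. Compound 2, `O=C(O)CC/C=C\CC1COC(c2cccc3ccccc23)OC1c1cccnc1`, gives 631 nM, and compound 1, `O=C(O)CC/C=C\CC1COC(c2ccco2)OC1c1cccnc1`, gives 1260 nM; both of these differences to compound 3 lie beyond the scatter. For the measured compounds named here, the only measured step, a 2.0-fold lower number from compound 1 to compound 2 (0.30 log units; within the scatter), changes a group on a saturated ring carbon and does not touch the place that separates compound 3 from compound 4.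

Compound 4, `CC(C)(Oc1ccccc1[N+](=O)[O-])C1OCC(C/C=C\CCC(=O)O)C(c2cccnc2)O1`, differs from compound 3 in this way: 2-nitrophenyl in place of 2-cyano-5-methylphenyl on an oxygen on a saturated carbon. Going by the values given here, no measured pair shows what an exchange at this oxygen does, so the step can be judged only from the fact that an aromatic ring with one acceptor gives way to one with two acceptors and no nitrile, a change of similar size on both sides.

Compound 4 is therefore expected to stay near compound 3, with a step in this assay of a 2.5-fold higher number from compound 3 to compound 4 (0.40 log units; beyond the scatter), at most a modest weakening. The estimate for compound 4 is 40 nM, with a range from 8 nM to 200 nM.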

Compound 4, dissociation constant: 11.2 nM
The estimate for compound 4 lay 3.6-fold (0.55 log units) above the measured number; low and high end bracket the measured number.
By their numbers in this assay, from the lowest: compounds 4 and 3 (each within the scatter of the next); then compounds 2 and 1 (each within the scatter of the next).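

In this assay, for the compounds shown here, the exchange on an oxygen on a saturated carbon gives a 1.4-fold lower number from compound 3 to compound 4 (0.15 log units; within the scatter), the first measured step at this place. It shows that 2-nitrophenyl can take the place of 2-cyano-5-methylphenyl, each with 9 heavy atoms and one six-membered aromatic ring, without a change beyond the scatter, even though the nitrile and the methyl both leave and a nitro group enters. The data shown offer no explanation of why these two groups read alike.

On these data alone, whether a plain phenyl, or a phenyl carrying an amine or a carboxylic acid, would read the same on this oxygen stays open. The compounds shown also do not separate what the nitrile and the methyl each contribute, since both leave in a single step.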